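A few compounds are considered here, and "the series" means these few. Any claim that something is new, unique, unknown or untested is made for them only; others in the source may bear on it.

Measured so far:
compound 1 `Nc1nc(N/N=C/c2ccc(OCc3ccc(F)cc3)cc2)nc2c1ncn2[C@@H]1O[C@H](CO)[C@@H](O)[C@H]1O` — 70 nM
compound 2 `Nc1nc(N/N=C/c2ccc(Br)cn2)nc2c1ncn2[C@@H]1O[C@H](CO)[C@@H](O)[C@H]1O` — 4.7 nM

Going by the values given here, compound 2 has the lower of the two numbers recorded in an assay on CHO-K1 cells for displacement of a labelled ligand from adenosine receptor A1 (Homo sapiens), read by scintillation counting, with a stated time of 60 min; on this read-out lower numbers stand for stronger inhibition and higher numbers for weaker inhibition; the only other number, that of compound 1, lies higher by a margin beyond the usual scatter, so compound 2 stands as the stronger binder of the pair. Compound 3 `CCCOc1ccc(/C=N/Nc2nc(N)c3ncn([C@@H]4O[C@H](CO)[C@@H](O)[C@H]4O)c3n2)cc1` has not been measured in this assay. It differs from compound 2 in one place: 4-propoxyphenyl in place of 5-bromopyridin-2-yl on a carbon with a double bond to nitrogen. Among the compounds with values here, no directly comparable single-point step exists between measured compounds; compound 1, however, also carries an oxygen-linked substituent on a phenyl ring in the corresponding position and gives 70 nM, a weaker result than compound 2. On that basis the change is expected to cost binding, with a step of an 8.5-fold higher number from compound 2 to compound 3 (0.93 log units; beyond the scatter) beyond the scatter and towards the value of compound 1. Compound 3 is estimated at 40 nM, within 10 nM to 150 nM.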

Compound 3, inhibition constant: > 10000 nM
Compound 3: no number, only a limit (the forecaster's own chance of this, stated with the estimate: 3%); at least 250-fold (2.39 log units) between middle value and limit.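

Compound 3 gives > 10000 nM in this assay, which is a limit of the assay and not a number: the limit of > 10000 nM in this assay, at which 1 of the 3 values shown sits.

At this carbon with a double bond to nitrogen, 4-propoxyphenyl in place of 5-bromopyridin-2-yl therefore brings a large loss, an at least 2100-fold higher number from compound 2 to compound 3 (3.32 log units; beyond the scatter). An oxygen-linked substituent on the phenyl ring does not by itself account for this loss, as ethyl in place of 4-fluorophenyl on the saturated chain carbon bound to that oxygen also gives a large step, an at least 140-fold higher number from compound 1 to compound 3 (2.15 log units; beyond the scatter).

The compounds shown leave open how much of the loss follows the propoxy chain and how much follows the exchange of the bromopyridinyl ring for a phenyl ring. A 4-bromophenyl group, a 4-methoxyphenyl group or an unsubstituted benzyloxy group at this place would help to separate these effects.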